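Series notes: aryl ether replacements on the shared core

This account rests on a few compounds, and the source may have more. Where it says the series, first, only, none or still open, it means among the compounds named here.

Measured so far:
- compound 1 `CC1(C)C(=O)Nc2ccc(OCc3ccc(F)cc3)cc21`: "not active" (no number reported)
- compound 2 `Cn1c(=O)[nH]c2ccc(OCc3ccc(Cl)cc3)cc21`: 8.29%
- compound 3 `Cn1c(=O)[nH]c2ccc(OCCCc3ccccc3)cc21`: 14%

In an assay on cells for inhibition of Amine oxidase [flavin-containing] B (Homo sapiens), read by fluorescence, with stated times of 30 min and 15 min, tested at 1 uM (a higher number here means more inhibition at the concentration tested (going by the name of the read-out), a lower number less inhibition), compound 1 gives "not active" (no number reported), so no single number stands for it; it is reported only as inactive at the concentration tested. Compound 2 and compound 3 share a core that differs from the core of compound 1, and in this assay compound 2 gives 8.29% while compound 3 gives 14%. These two values lie within the usual scatter of each other, so they show no order between the chloro-substituted benzyl ether and the three-carbon phenyl chain on that core; both sit low.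

Compound 4 `CC1(C)C(=O)Nc2ccc(OCCc3ccccc3)cc21` is not yet measured. It differs from compound 1 in one place: benzyl in place of 4-fluorophenyl on a saturated chain carbon bound to an oxygen on an aromatic ring. Among the measured compounds shown here, no step between measured compounds of the core of compound 1 exists, so the size of the step from compound 1 to compound 4 in this assay can only be guessed. Compound 1 is reported inactive. On the other core, compound 2 gives 8.29% and compound 3 gives 14%. Given these, any step from compound 1 to compound 4 is expected to stay within the scatter, in either direction. Compound 4 is estimated to give 9%, with a range from 0% to 24%.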

Compound 4, a percentage reported as inhibition, at one concentration (the size of the read-out at that concentration, not a potency): "not active" (no number reported)
No number was reported for compound 4; the estimate stays without a comparison.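

No step can be read between compound 1 and compound 4: in this assay compound 1 gives "not active" (no number reported) and compound 4 gives "not active" (no number reported) with no number for either. No measured evidence bears on this result. The compounds shown leave open whether benzyl in place of 4-fluorophenyl alters inhibition on the core of compound 1.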